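The source may hold more compounds than are shown below. What is called first, only, known or untested is meant among the compounds shown, and "the series" means these compounds.

Measured in a functional assay on LNCaP cells (Homo sapiens) for inhibition, read by MTT assay (a lower number here means a stronger inhibitor of growth, a higher number a weaker inhibitor of growth), so far:
compound 1 `CC1=C(/C=C/C(C)=C/C=C/C(C)=C\C(=O)Nc2ccccc2)C(C)(C)CCC1n1ccnc1`: 2690 nM
compound 2 `CC1=C(/C=C/C(C)=C/C=C/C(C)=C\C(=O)Nc2ccc(O)cc2)C(C)(C)CCC1n1ccnc1`: 3540 nM

Among the compounds with values here, compound 2 stands within the scatter of compound 1, and these are the only two values. Compound 3 `CC1=C(/C=C/C(C)=C/C=C/C(C)=C\C(=O)Nc2cccc(F)c2)C(C)(C)CCC1n1ccnc1` carries 3-fluorophenyl in place of 4-hydroxyphenyl on an amide-type nitrogen and has not been measured. Within the data shown here, the one measured step bearing on this, for hydroxy in place of hydrogen on an aromatic carbon, is a 1.3-fold higher number from compound 1 to compound 2 (0.12 log units; within the scatter) and lies within the scatter. Among the measured compounds shown here, no step for fluorine has been measured. Nothing beyond the scatter is therefore expected in this assay here. The expected step is a 1.2-fold lower number from compound 2 to compound 3 (0.07 log units; within the scatter) (an estimate). For compound 3 3000 nM is the estimated value, with 1200 nM to 7500 nM as the expected range.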

Compound 3, concentration for 50% growth inhibition: 2690 nM
Compound 3: middle estimate off by 1.1-fold (0.05 log units), on the high side; low and high end bracket the measured number.
By their numbers in this assay, from the lowest: compounds 1, 3 and 2 (each within the scatter of the next).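

In this assay, the swap on the amide-type nitrogen gives a 1.3-fold lower number from compound 2 to compound 3 (0.12 log units; within the scatter), and fluoro in place of hydrogen on an aromatic carbon gives no change at the digits printed from compound 1 to compound 3 (within the scatter). Phenyl, 4-hydroxyphenyl and 3-fluorophenyl on this nitrogen therefore give numbers within the scatter of one another, even though the 3-fluorophenyl group counts no hydrogen-bond donor or acceptor. No supporting measurement bears on this result. Left open is whether an amine, a carboxylic acid or a trifluoromethyl group on the aromatic ring, or a benzyl group on the amide-type nitrogen, gives a number beyond the scatter.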